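From an Amino Acid Tail to an Ester Tail

The source may hold more compounds than are shown below. What is called first, only, known or untested is meant among the compounds shown, and "the series" means these compounds.

Of the compounds shown here, three sharing one core have been measured in a functional assay on HepG2 cells (Homo sapiens) for inhibition, read by MTT assay, with a stated time of 3 days; on this read-out higher numbers stand for weaker inhibition and lower numbers for stronger inhibition. Compound 1 `CC[C@H](C)[C@H](NCC(=O)NNC(=O)COc1ccc(-c2nc3ccccc3s2)cc1OC)C(=O)O` gives 3540 nM. Compound 2 `COc1cc(-c2nc3ccccc3s2)ccc1OCC(=O)NNC(=O)CN[C@@H](CS(=O)(=O)O)C(=O)O` gives 3690 nM in this assay, and compound 3 `COc1cc(-c2nc3ccccc3s2)ccc1OCC(=O)NNC(=O)CN1CCC[C@H]1C(=O)O` gives 2650 nM. On these numbers compound 1 holds the second highest of the three; its nearest neighbour is compound 2, with a 1.0-fold higher number from compound 1 to compound 2 (0.02 log units; within the scatter), and the furthest is compound 3, with a 1.3-fold lower number from compound 1 to compound 3 (0.13 log units; within the scatter). The remaining step, a 1.4-fold lower number from compound 2 to compound 3 (0.14 log units; within the scatter), is equally small.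

Compound 4 `CCOC(=O)CN(C)CC(=O)NNC(=O)COc1ccc(-c2nc3ccccc3s2)cc1OC` is the next to be measured. It differs from compound 1 by ((ethoxycarbonyl)methyl)(methyl)amino in place of (1-carboxy-2-methylbutyl)amino on a saturated chain carbon bound to a carbonyl carbon. The measured steps each swap one acid-bearing side group for another, and every one of them stayed within the scatter. None of them changes the count of hydrogen-bond donors, as this change does, so they bear on it only loosely. The expectation for compound 4 is therefore a step of a 1.1-fold lower number from compound 1 to compound 4 (0.04 log units; within the scatter), with no firm direction. Compound 4 is estimated at 3200 nM, expected to lie between 1400 nM and 7500 nM.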

Compound 4, half-maximal inhibitory concentration: 3180 nM
Beside the measured number, compound 4's estimate is 1.0-fold (0.00 log units) above it; low and high end bracket the measured number.
By their numbers in this assay, from the lowest: compounds 3, 4, 1 and 2 (each within the scatter of the next).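

In this assay, among these compounds, putting ((ethoxycarbonyl)methyl)(methyl)amino, with 0 hydrogen-bond donors, in place of (1-carboxy-2-methylbutyl)amino, with 2, gives (a 1.1-fold lower number from compound 1 to compound 4 (0.05 log units; within the scatter)), the first measured change here that removes the free carboxylic acid and the donor count with it. The comparisons with the other two acid-bearing compounds read the same way (a 1.2-fold higher number from compound 3 to compound 4 (0.08 log units; within the scatter)) and (a 1.2-fold lower number from compound 2 to compound 4 (0.06 log units; within the scatter)), so among these four compounds, a free acid on this saturated chain carbon bound to a carbonyl carbon is not required to keep the number within the scatter. Nothing available explains why these different groups give such similar numbers.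

The compounds shown leave open whether a group with no ester or acid at all, such as a plain dimethylamino group, would fit the same picture. A primary amine or a longer alkyl chain at this place also remains an open question.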